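Methoxy placement on the arylpiperazine of the coumarin amides

The source may report more compounds than this note shows. Statements on the series, on what has been measured and on what is new or still open speak of the compounds shown alone.

Two compounds of the series have numbers in a functional assay for antagonist activity at Adrenergic receptor alpha-1 (Rattus norvegicus); a higher number here means weaker binding, a lower number tighter binding. Compound 1 `COc1ccc(Cl)cc1N1CCN(CCNC(=O)c2cc3ccccc3oc2=O)CC1` gives 49 nM and compound 2 `COc1ccccc1N1CCN(CCNC(=O)c2cc3ccccc3oc2=O)CC1` gives 19.5 nM. For the measured compounds named here, the single one-place step so far is a 2.5-fold lower number from compound 1 to compound 2 (0.40 log units; beyond the scatter). Going by the values given here, compound 2 therefore stands at the lowest of the two numbers, with compound 1 as its only neighbour.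

Compound 3 `COc1ccc(N2CCN(CCNC(=O)c3cc4ccccc4oc3=O)CC2)cc1` is not yet measured. It differs from compound 2 by 4-methoxyphenyl in place of 2-methoxyphenyl on an amine nitrogen in a ring; the two have the same atoms, joined differently. Among the compounds with values here, no measured step bears directly on this change: the step from compound 1 to compound 2 concerns a chloro on an aromatic carbon, not where the methoxy sits, and shows only that one-place changes have so far moved the number modestly. Within the data shown here, with no bearing step the direction is open and the range is kept wide. The expected step for compound 3 is a 6.2-fold higher number from compound 2 to compound 3 (0.79 log units; beyond the scatter), toward a higher number. The estimate for compound 3 is 120 nM, with a range from 30 nM to 500 nM.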

Compound 3, dissociation constant: 18.2 nM
Compound 3: the middle estimate sits 6.6-fold (0.82 log units) above what was measured; the measured number lies below the stated range.
By their numbers in this assay, from the lowest: compounds 3 and 2 (each within the scatter of the next); then compound 1.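

Placing the methoxy as 4-methoxyphenyl rather than 2-methoxyphenyl on the amine nitrogen in the ring gives a 1.1-fold lower number from compound 2 to compound 3 (0.03 log units; within the scatter) in this assay, so these two placements cannot be told apart here. For the compounds shown here, with a 2.7-fold lower number from compound 1 to compound 3 (0.43 log units; beyond the scatter), the 5-chloro-2-methoxyphenyl group of compound 1 remains the one aryl group of the three that stands apart, and this is the second step beyond the scatter to reach it. Nothing accompanying these numbers explains why the methoxy placement leaves no visible difference.

From the compounds shown here alone, it remains open whether this indifference to placement extends to a hydroxyl or an amine in place of the methoxy, or to a plain phenyl. Also open, going by these compounds, is whether a longer chain carrying the coumarin amide would keep the same picture.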